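The source may report more compounds than this note shows. Statements on the series, on what has been measured and on what is new or still open speak of the compounds shown alone.

Measured compounds in a functional assay on UO-31 cells (Homo sapiens) for cytotoxicity, read by sulforhodamine B assay, with a stated time of 48 h, tested at 1 uM; on this read-out lower numbers stand for a stronger effect and higher numbers for a weaker effect at the one concentration tested:
Compound 1 `COc1cc(C)cc(-c2c(-c3ccnc(-c4ccc(C(C)=O)cc4)c3)cnn2CC#N)c1` gives 11%.
Compound 2 `Cc1cc(O)cc(-c2nn(CC#N)cc2-c2ccnc(-c3ccc(Oc4ccccc4)cc3)c2)c1` gives 19%.
Compound 3 `COc1cc(C)cc(-c2nn(CC#N)cc2-c2ccnc(-c3ccc(N(C)C)cc3)c2)c1` gives 18%.

On these three numbers compound 3 stands second highest; its nearest neighbour is compound 2, whose number is one point higher, and its furthest is compound 1, whose number is seven points lower. Both gaps lie within the usual scatter of such measurements, so the three compounds cannot be told apart in this assay on this evidence.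

Compound 4 `Cc1cc(O)cc(-c2nn(CC#N)cc2-c2ccnc(-c3ccc(N(C)C)cc3)c2)c1` differs from compound 3 in one place: hydrogen in place of methyl on an oxygen on an aromatic ring. Compound 2 carries the same hydroxy group, though with a different group on its far ring, and its value sits alongside those of compounds 1 and 3. No comparison between two measured compounds differing only in this way is available, so nothing points to a step beyond the scatter, in either direction, in this assay.

Compound 4 is therefore expected to give 18% in this assay, between 7% and 30%, which means an expected step of no change at the digits printed from compound 3 to compound 4 (within the scatter).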

Compound 4, a percentage reported as activity, at one concentration (the size of the read-out at that concentration, not a potency): 19%
Compound 4: middle estimate off by 1 percentage points, on the low side; the measured number falls inside the stated range.
By their numbers in this assay, from the lowest: compounds 1, 3, 2 and 4 (each within the scatter of the next).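

In this assay, for the compounds shown here, the earlier compounds offered no pair differing only at this oxygen on an aromatic ring; the change from methoxy to hydroxy now gives a number 1 percentage points higher from compound 3 to compound 4 (within the scatter), so this one change, in this setting, leaves the read-out within the scatter at the single concentration tested. Compound 4 also provides a pair differing only on an aromatic carbon, where dimethylamino in place of phenoxy gives no change at the digits printed from compound 2 to compound 4 (within the scatter), again within the scatter. Nothing available bears on why either change leaves the number within the scatter.

On these data alone, whether an ethoxy group or a longer alkoxy chain on this oxygen, or an amine in place of the oxygen, would stay within the scatter remains open. So does whether these pairs would differ at other concentrations or in other cells.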